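This account rests on a few compounds, and the source may have more. Where it says the series, first, only, none or still open, it means among the compounds named here.

Of the compounds shown here, three built on one shared core have been tested in a functional assay on MCF7 cells (Homo sapiens) for cytotoxicity, read by MTT assay, with a stated time of 72 h; a higher number here means a weaker inhibitor, a lower number a stronger inhibitor. Compound 1 `COc1cccc(/C=C2\CCC/C(=C\c3ccccc3Cl)C2=O)c1OC` gives 11300 nM, compound 2 `COc1cccc(/C=C2\CCC/C(=C\c3cccc(Cl)c3)C2=O)c1OC` gives 12000 nM, and compound 3 `COc1cccc(/C=C2\CCC/C(=C\c3cccc(O)c3)C2=O)c1OC` gives 8800 nM. On these numbers, compound 3 stands within the scatter of both other compounds, so the three cannot be ranked. The next compound, compound 4 `COc1cccc(/C=C2\CCC/C(=C\c3cc(Cl)cc(Cl)c3)C2=O)c1OC`, differs from compound 3 at one place: 3,5-dichlorophenyl in place of 3-hydroxyphenyl on a double-bonded chain carbon bound to a double-bonded ring carbon.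

For the measured compounds named here, three measured steps bear on this change. Moving from 2-chlorophenyl to 3-chlorophenyl gave a 1.1-fold higher number from compound 1 to compound 2 (0.03 log units; within the scatter). Placing 3-hydroxyphenyl in the same position gave a 1.3-fold lower number from compound 1 to compound 3 (0.11 log units; within the scatter), and hydroxy in place of chloro on an aromatic carbon gave a 1.4-fold lower number from compound 2 to compound 3 (0.13 log units; within the scatter). Going by the values given here, all three steps are small, but no measured compound carries 3,5-dichlorophenyl, so that exact group remains untested. In this assay, no change beyond the scatter is therefore expected, with an estimated 1.1-fold higher number from compound 3 to compound 4 (0.06 log units; within the scatter). For compound 4, the estimated value is 10000 nM, with an expected range of 5000 nM to 20000 nM.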

Compound 4, half-maximal inhibitory concentration: 4300 nM
The estimate for compound 4 lay 2.3-fold (0.37 log units) above the measured number, and the stated range ends above it.
By their numbers in this assay, from the lowest: compound 4; then compounds 3, 1 and 2 (each within the scatter of the next).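

In this assay, this position now shows a change beyond the scatter: 3,5-dichlorophenyl gives a 2.0-fold lower number from compound 3 to compound 4 (0.31 log units; beyond the scatter), whereas the earlier changes here stayed within it. Chloro in place of hydrogen on an aromatic carbon gives a 2.8-fold lower number from compound 2 to compound 4 (0.45 log units; beyond the scatter), and 3,5-dichlorophenyl in place of 2-chlorophenyl gives a 2.6-fold lower number from compound 1 to compound 4 (0.42 log units; beyond the scatter), so among these four compounds, the one with two chloro groups stands apart from the other three, though each step is modest. Nothing measured here accounts for this difference.

The compounds shown leave open whether the two chloro groups themselves matter, or whether 3,5-difluorophenyl or 3,5-dimethylphenyl would give a similar number. On these data alone, how an amine or a carboxylic acid on the aromatic ring would read also remains open.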